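The source may report more compounds than this note shows. Statements on the series, on what has been measured and on what is new or still open speak of the compounds shown alone.

Values measured in a physicochemical assay for solubility, read by HPLC, in phosphate buffer, with a stated time of 24 h, at pH 7.4, tested at 100 uM; a lower number here means a less soluble compound, a higher number a more soluble compound:
- compound 1 `O=C(CCCCCNc1c(Nc2ccc(C(F)(F)F)cc2)c(=O)c1=O)NO`: 4500000 nM
- compound 2 `COc1ccc(Nc2c(NC(C)CCCCC(=O)NO)c(=O)c2=O)cc1`: 85000000 nM
- compound 3 `CC(CCCCC(=O)NO)Nc1c(Nc2ccc(C(F)(F)F)cc2)c(=O)c1=O`: 30000000 nM

In this assay, compound 3 stands second highest of the three numbers, under compound 2 and over compound 1. Compound 4 `CCC(CCCCC(=O)NO)Nc1c(Nc2ccc(C(F)(F)F)cc2)c(=O)c1=O` departs from compound 3 by methyl in place of hydrogen on a saturated chain carbon, two bonds along the chain from a nitrogen on an aromatic ring. The same difference reads methyl to ethyl.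

The nearest measured evidence is a 6.7-fold higher number from compound 1 to compound 3 (0.82 log units; beyond the scatter), a modest step that also adds methyl on the chain, though on the carbon bound to the nitrogen. The other measured step, a 2.8-fold lower number from compound 2 to compound 3 (0.45 log units; beyond the scatter), is also modest but concerns the aromatic carbon and bears on this change only weakly. For the measured compounds named here, no measured step extends a methyl to an ethyl, so the direction is open and no step beyond the scatter is expected. The expected step is a 1.4-fold lower number from compound 3 to compound 4 (0.13 log units; within the scatter). For compound 4 the estimate is 22000000 nM, with an expected range of 7000000 nM to 60000000 nM.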

Compound 4, solubility: 6600000 nM
Compound 4: middle estimate off by 3.3-fold (0.52 log units), on the high side; measured number outside the range, below it.
By their numbers in this assay, from the lowest: compounds 1 and 4 (each within the scatter of the next); then compound 3; then compound 2.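

In this assay, methyl to ethyl proves a real step (a 4.5-fold lower number from compound 3 to compound 4 (0.66 log units; beyond the scatter)) and runs opposite to the earlier methyl in place of hydrogen (a 6.7-fold higher number from compound 1 to compound 3 (0.82 log units; beyond the scatter)). Read against the unbranched compound, the ethyl leaves only a difference within the scatter (a 1.5-fold higher number from compound 1 to compound 4 (0.17 log units; within the scatter)), so the higher number of compound 3 does not carry over to the ethyl of compound 4. Nothing measured here accounts for this reversal.

On these data alone, whether an isopropyl, or a chain ending in an amine or a carboxylic acid, at this carbon would follow compound 3 or compound 4 stays open. Also open, as far as these compounds go, is whether methoxy in place of trifluoromethyl on an aromatic carbon would move the ethyl compound as it moves the methyl pair.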